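Triazole substituent changes at the limit of this series

A few compounds are considered here, and "the series" means these few. Any claim that something is new, unique, unknown or untested is made for them only; others in the source may bear on it.

Compound 1 `O=C1O[C@H]([C@@H](O)Cn2cc(-c3cc(F)cc(F)c3)nn2)C(OCc2ccccc2)=C1OCc1ccccc1` gives 41200 nM in a functional assay on A549 cells (Homo sapiens) for antiproliferative activity, read by MTT assay, with a stated time of 72 h; on this read-out lower numbers stand for stronger inhibition and higher numbers for weaker inhibition. Compound 2 `O=C1O[C@H]([C@@H](O)Cn2cc(CNS(=O)(=O)c3ccc(F)cc3)nn2)C(OCc2ccccc2)=C1OCc1ccccc1` gives 22500 nM in this assay, and the move a 1.8-fold lower number from compound 1 to compound 2 (0.26 log units; within the scatter) is small. Compound 3 `O=C1O[C@H]([C@@H](O)Cn2cc(CCO)nn2)C(OCc2ccccc2)=C1OCc1ccccc1` reaches only a limit in this assay, > 100000 nM. Compound 3 therefore stands at the top of the numbers shown, sitting at the limit of > 100000 nM in this assay, at which 1 of the 3 values shown sits; both an at least 2.4-fold higher number from compound 1 to compound 3 (0.38 log units; beyond the scatter) and an at least 4.4-fold higher number from compound 2 to compound 3 (0.64 log units; beyond the scatter) go beyond the scatter, so the 2-hydroxyethyl group on the triazole weakens inhibition against either aryl-bearing analogue.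

Compound 4 `O=C1O[C@H]([C@@H](O)Cn2cc(C3CC3)nn2)C(OCc2ccccc2)=C1OCc1ccccc1` is the next step from compound 3: cyclopropyl in place of 2-hydroxyethyl on an aromatic carbon. Within the data shown here, the steps that bear on it are an at least 2.4-fold higher number from compound 1 to compound 3 (0.38 log units; beyond the scatter) and an at least 4.4-fold higher number from compound 2 to compound 3 (0.64 log units; beyond the scatter), each moving the number upward when a hydroxyl-bearing chain replaced the 3,5-difluorophenyl or the (((4-fluorophenyl)sulfonyl)amino)methyl group. Going the other way, from 2-hydroxyethyl to cyclopropyl, the expectation is a move back toward the measurable range, though cyclopropyl is far smaller than either group in compound 1 or compound 2, so the expected step of an at least 1.4-fold lower number from compound 3 to compound 4 (0.15 log units; that floor lies within the scatter) is modest and may not clear the limit. Compound 4 is estimated at 70000 nM, within 30000 nM to 160000 nM.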

Compound 4, half-maximal inhibitory concentration: 43900 nM
The estimate for compound 4 lay 1.6-fold (0.20 log units) above the measured number, within the range that was stated.
By their numbers in this assay, from the lowest: compounds 2, 1 and 4 (each within the scatter of the next). At a limit, above all of these: compound 3.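

On the aromatic carbon of the triazole, replacing 2-hydroxyethyl with cyclopropyl, with 3 heavy atoms on each side of the change, gives a clear step out of the limit, an at least 2.2-fold lower number from compound 3 to compound 4 (0.35 log units; beyond the scatter), so losing the hydroxyl-bearing chain matters here even though the heavy-atom count stays the same. Neither aryl nor sulfonyl content is needed for a measurable number in this small set, since cyclopropyl cannot be told apart from the (((4-fluorophenyl)sulfonyl)amino)methyl group, a 2.0-fold higher number from compound 2 to compound 4 (0.29 log units; within the scatter), or from 3,5-difluorophenyl, a 1.1-fold higher number from compound 1 to compound 4 (0.03 log units; within the scatter). Compound 3 is now the only compound of the four at a limit in this assay: the limit of > 100000 nM in this assay, at which 1 of the 4 values shown sits.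

Whether the hydroxyl or the open chain drives the step stays unresolved, and an ethyl or propyl group, a 2-methoxyethyl chain or a 2-aminoethyl chain on the same carbon would separate the two. As far as these compounds go, compounds 1, 2 and 4 lie within the scatter of their neighbours in the ranking, so it also stays open whether any group at this position, such as a carboxylic acid, a basic amine or an unsubstituted phenyl, can move the number well away from theirs.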